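A few compounds are considered here, and "the series" means these few. Any claim that something is new, unique, unknown or untested is made for them only; others in the source may bear on it.

Measured so far:
- compound 1, `COc1ccccc1NC1=CC(=O)c2c(nc3n2[C@H]2OC[C@@H](O)[C@H]2OC3)C1=O`, in a functional assay on ECa-109 cells for inhibition, with ECa-109 cell line (Homo sapiens) as the target, read by sulforhodamine B assay; on this read-out higher numbers stand for weaker inhibition and lower numbers for stronger inhibition: > 4000 nM
- compound 2, `O=C1C(Nc2ccccc2F)=CC(=O)c2c1nc1n2[C@H]2OC[C@@H](O)[C@H]2OC1`, in this assay: 2660 nM
- compound 3, `CCc1ccc(NC2=CC(=O)c3c(nc4n3[C@H]3OC[C@@H](O)[C@H]3OC4)C2=O)cc1`, in this assay: > 4000 nM

The three compounds share one core and differ only in the group on the amine nitrogen. The value for compound 1 is a limit of the assay, not a number. The value for compound 3 is likewise a limit of the assay. Going by the values given here, two of the three values sit at the limit of > 4000 nM in this assay, at which 2 of the 3 values shown sit, so compound 3 stands at the weak end of what this assay can report, with compound 2 as the only compound given a number.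

The measured steps that reach compound 3 give little to go on: an at least 1.5-fold higher number from compound 2 to compound 3 (0.17 log units; that floor lies within the scatter), and a step that the two limits leave unreadable from compound 1 to compound 3.

Compound 4 is `O=C1C(N2CCC2)=CC(=O)c2c1nc1n2[C@H]2OC[C@@H](O)[C@H]2OC1`. Its change from compound 3 is azetidin-1-yl in place of (4-ethylphenyl)amino on a double-bonded ring carbon. No measured step swaps the arylamine for a small saturated ring of this kind, so none of the steps shown bears directly on it, and no direction can be read from them. The expectation is therefore that the number for compound 4 stays near where compound 3 sits, as a step that the limit leaves unreadable from compound 3 to compound 4, with a wide range. The estimate for compound 4 in this assay is 4500 nM, ranging from 1500 nM to 15000 nM.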

Compound 4, half-maximal inhibitory concentration: > 16000 nM
Compound 4 was reported as a limit; the forecaster's own chance of this, stated with the estimate: 60%; middle value at least 3.5-fold (0.55 log units) away from the limit.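

Going by these compounds alone, replacing the (2-fluorophenyl)amino group with azetidin-1-yl on this double-bonded ring carbon gives an at least 6.0-fold higher number from compound 2 to compound 4 (0.77 log units; beyond the scatter) in this assay, the first step at this position that lies clearly beyond the scatter. Compound 4 is reported only as a limit of the assay, not as a number, and it is alone at that limit: the limit of > 16000 nM in this assay, at which 1 of the 4 values shown sits. The steps that join compound 4 to compound 1 and to compound 3 cannot be read, because both ends of each step are limits: the limit of > 4000 nM in this assay, at which 2 of the 4 values shown sit.

In the one readable step, the aromatic ring and the amine hydrogen-bond donor leave together, so the compounds shown cannot tell which of the two losses matters, or whether both do. From the compounds shown here alone, it also stays open whether a larger saturated ring such as piperidine, or an open chain such as propylamine that keeps the amine hydrogen, would behave more like compound 2 or more like compound 4.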